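The compounds below may be only part of what the source reports. "The series", "measured", "known", "first", "only" and "open" are said of these compounds alone.

Of the compounds shown here, three sharing one core have been tested in an ADME assay on L6 cells (Rattus norvegicus) for cytotoxicity, with a stated time of 72 h; a lower number here means a stronger inhibitor, a higher number a weaker inhibitor: compound 1 `CC(C)(C)C(=O)OC1CC2(N3CCCC3)CC(c3ccccc3)C1C(c1ccccc1)C2` gives 7620 nM, compound 2 `CN(C)C12CC(OC(=O)C(C)(C)C)C(C(c3ccccc3)C1)C(c1ccccc1)C2` gives 5060 nM, and compound 3 `CC(C)(C)C(=O)OC1CC2(N3CCCCC3)CC(c3ccccc3)C1C(c1ccccc1)C2` gives 12000 nM. They differ only in the amine on a saturated ring carbon. Compound 3 cannot be told apart from one of its neighbours, with a 1.6-fold higher number from compound 1 to compound 3 (0.20 log units; within the scatter), and stands modestly apart from the other, with a 2.4-fold higher number from compound 2 to compound 3 (0.38 log units; beyond the scatter). The remaining step, a 1.5-fold lower number from compound 1 to compound 2 (0.18 log units; within the scatter), is also small.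

Compound 4 `O=C(CN1CCCCC1)OC1CC2(N3CCCCC3)CC(c3ccccc3)C1C(c1ccccc1)C2` keeps the piperidin-1-yl of compound 3 and changes the other end of the molecule: (piperidin-1-yl)methyl in place of tert-butyl on a carbonyl carbon. In words, (piperidin-1-yl)methyl takes the place of tert-butyl on a carbonyl carbon. For the measured compounds named here, no measured step touches that carbonyl carbon, so the data give no direct guide to this change. The only yardstick is the largest amine swap, a 2.4-fold higher number from compound 2 to compound 3 (0.38 log units; beyond the scatter), so a clear shift in this assay is not expected, and the range must stay wide. The expected change is a 1.2-fold higher number from compound 3 to compound 4 (0.07 log units; within the scatter). For compound 4 the estimated value is 14000 nM, with an expected range of 4500 nM to 45000 nM.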

Compound 4, half-maximal inhibitory concentration: 60400 nM
Estimate against measurement, compound 4: 4.3-fold (0.63 log units) below; measured number outside the range, above it.
By their numbers in this assay, from the lowest: compounds 2, 1 and 3 (each within the scatter of the next, the first and the last beyond it); then compound 4.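

The carbonyl carbon that carries tert-butyl in compound 3 proves to be a position where this assay responds: (piperidin-1-yl)methyl there gives a 5.0-fold higher number from compound 3 to compound 4 (0.70 log units; beyond the scatter), a modest shift but one beyond the scatter. The amine swaps had reached at most a 2.4-fold higher number from compound 2 to compound 3 (0.38 log units; beyond the scatter), so this first look at the other end of the molecule shows that it too can move the number, here towards a weaker inhibitor. Nothing available explains this shift.

A single swap brings in a ring and a nitrogen together, so the compounds shown cannot say which of the two goes with the higher number. Cyclohexylmethyl, which has a ring without the nitrogen, and (dimethylamino)methyl, which has the nitrogen without a ring, would separate them, and whether the step changes with a different amine on the saturated ring carbon also remains open.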